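A few compounds are considered here, and "the series" means these few. Any claim that something is new, unique, unknown or untested is made for them only; others in the source may bear on it.

Of the compounds shown here, three have so far been tested in an ADME assay on L02 cells (Homo sapiens) for cytotoxicity, read by MTT assay, with a stated time of 48 h; a lower number here means a stronger inhibitor, a higher number a weaker inhibitor. Compound 1 `COc1ccc2[nH]c(=O)c(-c3nc4ccccc4[nH]3)cc2c1` returns only a limit, > 100000 nM. Compound 2 `Cc1ccc2[nH]c(=O)c(-c3nc4cc(Cl)ccc4[nH]3)cc2c1` likewise returns a limit, > 100000 nM. Compound 3 `Cc1cc2nc(-c3cc4ccccc4[nH]c3=O)[nH]c2cc1C` also returns a limit, > 100000 nM. Compound 2 therefore stands with the other two at the limit of > 100000 nM in this assay, at which 3 of the 3 values shown sit, and no numbered value separates any of them.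

Compound 4 `Cc1ccc2[nH]c(=O)c(-c3nc4cc(Br)ccc4[nH]3)cc2c1` differs from compound 2 by bromo in place of chloro on an aromatic carbon. Within the data shown here, no step between measured compounds is available to size this change, so only an expectation can be given: in this assay a step of no more than the usual scatter, in no clear direction, is expected. Compound 4 is accordingly expected to give about 150000 nM, within a range from 100000 nM to 300000 nM. The expected step amounts to a step that the limit leaves unreadable from compound 2 to compound 4.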

Compound 4, half-maximal inhibitory concentration: > 100000 nM
Compound 4 ended at the assay's limit; the forecaster's own chance of this, stated with the estimate: 90%; the middle value is on the limit's open side.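

Compound 2 and compound 4 both return only a limit in this assay, so no step from chloro to bromo can be read: the limit of > 100000 nM in this assay, at which 4 of the 4 values shown sit.

The compounds shown leave open how far any of them lies past that limit, and whether bromo and chloro differ here at all.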